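The compounds below may be only part of what the source reports. "The series", "measured", "known", "first", "only" and "open" are said of these compounds alone.

Compound 3 `O=S(=O)(Nc1ccc(-c2nc3ccccc3o2)cc1)c1ccc(F)cc1` in an assay on isolated protein for inhibition of malate dehydrogenase, mitochondrial (Sus scrofa), with stated times of 45 min and 30 min (a lower number here means a stronger inhibitor, a higher number a weaker inhibitor), gives > 63000 nM, which is a limit of the assay and not a number. Compound 1 `CS(=O)(=O)Nc1ccc(-c2nc3ccccc3o2)cc1` gives > 63000 nM, also a limit. Compound 2 `O=S(=O)(Nc1ccc(-c2nc3ccccc3o2)cc1)c1cccc(F)c1` gives > 63000 nM, again a limit. All three values sit at the limit of > 63000 nM in this assay, at which 3 of the 3 values shown sit, so the steps a step that the two limits leave unreadable from compound 1 to compound 2, a step that the two limits leave unreadable from compound 1 to compound 3 and a step that the two limits leave unreadable from compound 2 to compound 3 cannot be read in either size or direction. Compound 4 `O=S(=O)(Nc1ccc(-c2nc3ccccc3o2)cc1)c1ccc(O)cc1` differs from compound 3 in hydroxy in place of fluoro on an aromatic carbon. Among the measured compounds shown here, no measured step involves a hydroxy group, so none of the three bears on this change. The expected step is a step that the limit leaves unreadable from compound 3 to compound 4, not beyond the scatter, since compound 3 itself stands at the limit > 63000 nM. Compound 4 is therefore estimated at 100000 nM, within 20000 nM to 500000 nM.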

Compound 4, half-maximal inhibitory concentration: > 63000 nM
Compound 4 ended at the assay's limit (the forecaster's own chance of this, stated with the estimate: 80%); the middle value lies beyond the limit too.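

In this assay compound 4 gives > 63000 nM, a limit and not a number, so no step to compound 4 from compound 1, compound 2 or compound 3 can be read: the limit of > 63000 nM in this assay, at which 4 of the 4 values shown sit.

The compounds shown leave open what change to the shared core or its sulfonyl group would bring a readable value in this assay.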